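The source may hold more compounds than are shown below. What is called first, only, known or untested is meant among the compounds shown, and "the series" means these compounds.

Values measured so far in a functional assay on L1210 cells (Mus musculus) for inhibition, with a stated time of 96 h (on this read-out higher numbers stand for weaker inhibition and lower numbers for stronger inhibition), are:

- compound 1 `CCNCCCNCCCNCC` gives 10000 nM
- compound 2 `CCNCCCCNCCCN` gives 40000 nM
- compound 3 `CCCNCCCCNCCCN` gives 55000 nM

Compound 3 at 55000 nM lies within the scatter of compound 2. Its number is clearly higher than that of compound 1 at 10000 nM and so stands for weaker inhibition.

Compound 4 `CCCNCCCCCNCCCCNCCC` is the compound now in question, and it differs from compound 3 as follows: 2-(propylamino)ethyl in place of amino on a saturated chain carbon, three bonds along the chain from an amine nitrogen. The amino group of compound 3 is therefore gone.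

Within the data shown here, the only measured step is a 1.4-fold higher number from compound 2 to compound 3 (0.14 log units; within the scatter) and it lies within the scatter. That step is a methyl exchange at another place, so it says little about this change. Among the measured compounds shown here, no measured step isolates the loss of the amino group. The nearest guide is compound 1 at 10000 nM which also carries no amino group and has a lower number than the two compounds that do. This rests on a single compound whose chain differs from that of compound 4, so the expectation is loose: a move to a lower number, probably beyond the scatter.

The step expected is a 3.7-fold lower number from compound 3 to compound 4 (0.56 log units; beyond the scatter) and it remains tentative. Compound 4 is estimated at 15000 nM with an expected range from 4000 nM to 50000 nM as the working span.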

Compound 4, half-maximal inhibitory concentration: 1200 nM
For compound 4 the middle estimate is 13-fold (1.10 log units) above the measured one; the whole stated range lies above it.
By their numbers in this assay, from the lowest: compound 4; then compound 1; then compounds 2 and 3 (each within the scatter of the next).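

In this assay, 2-(propylamino)ethyl in place of amino on a saturated chain carbon, three bonds along the chain from an amine nitrogen, gives a 46-fold lower number from compound 3 to compound 4 (1.66 log units; beyond the scatter) and so moves the number far more than the methyl exchange did. That earlier exchange, a 1.4-fold higher number from compound 2 to compound 3 (0.14 log units; within the scatter), left the number within the scatter, so this is the first single change in the series shown to bring a large move towards stronger inhibition. The exchange replaces a single heavy atom with a group of 6 heavy atoms, and no data at hand give a reason for the fall in the number.

The compounds shown do not separate the added carbon chain from the added nitrogen, as the entering group brings both in one step. A plain pentyl group at this place, which keeps the carbon chain and carries no nitrogen, would set the two apart, while a longer chain bearing a further amine would show whether the fall in the number continues beyond 2-(propylamino)ethyl.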